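Methoxy for Fluoro on the Benzyl Arm

The source may hold more compounds than are shown below. What is called first, only, known or untested is meant among the compounds shown, and "the series" means these compounds.

Measured in a functional assay on BT-549 cells (Homo sapiens) for inhibition, read by sulforhodamine B assay, with a stated time of 48 h; a higher number here means a weaker inhibitor of growth, a lower number a stronger inhibitor of growth:
compound 1 `COc1ccc(CNc2nc3cc(N)cc(N)c3nc2-c2ccccc2)cc1OC` gives 13500 nM
compound 2 `COc1cc(CNc2nc3cc(N)cc(N)c3nc2-c2ccccc2)cc(OC)c1OC` gives 3800 nM
compound 3 `Nc1cc(N)c2nc(-c3ccccc3)c(NCc3ccc(F)cc3)nc2c1` gives 1700 nM

Compound 3 stands lowest of the three, with compound 2 nearest and compound 1 furthest. Compound 4 `COc1ccc(CNc2nc3cc(N)cc(N)c3nc2-c2ccccc2)cc1` differs from compound 3 by methoxy in place of fluoro on an aromatic carbon. Within the data shown here, no measured step exchanges exactly these two groups. The nearest is a 7.9-fold lower number from compound 1 to compound 3 (0.90 log units; beyond the scatter), where a fluoro-bearing arm replaced a dimethoxy-bearing one, while a 3.6-fold lower number from compound 1 to compound 2 (0.55 log units; beyond the scatter) shows a further methoxy on that arm lowering the number. A single methoxy on compound 4 is therefore expected to sit between these cases, so the step from compound 3 to compound 4 is estimated as a 2.1-fold higher number from compound 3 to compound 4 (0.31 log units; beyond the scatter) in this assay. Compound 4 is expected at 3500 nM, within 1200 nM to 10000 nM.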

Compound 4, concentration for 50% growth inhibition: 6460 nM
Estimate against measurement, compound 4: 1.8-fold (0.27 log units) below, within the range that was stated.
By their numbers in this assay, from the lowest: compound 3; then compounds 2 and 4 (each within the scatter of the next); then compound 1.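

Within this assay, the exchange of 4-fluorobenzyl for 4-methoxybenzyl gives a 3.8-fold higher number from compound 3 to compound 4 (0.58 log units; beyond the scatter) and is the first direct reading of these two groups at this carbon. Removing one methoxy from the arm of compound 1 gives a 2.1-fold lower number from compound 1 to compound 4 (0.32 log units; beyond the scatter) and, set against a 3.6-fold lower number from compound 1 to compound 2 (0.55 log units; beyond the scatter), shows that the number does not fall steadily as methoxy groups are added to the arm. Nothing available accounts for either step. The compounds shown leave open how chloro, trifluoromethyl or an amine would read at this same carbon.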